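Swapping a Fused Ring Tail for a Simple Benzyl

The source may hold more compounds than are shown below. What is called first, only, known or untested is meant among the compounds shown, and "the series" means these compounds.

For the measured compounds named here, compound 1 `CCCSc1nc(Cl)c2c(n1)N(Cc1ccccc1)C(C(=O)NCCC1=CCc3ccccc31)N2` gives 48800 nM in a functional assay on A549 cells (Homo sapiens) for antiproliferative activity, read by MTT assay, with a stated time of 72 h (a lower number here means a stronger inhibitor, a higher number a weaker inhibitor), the higher of the two numbers measured so far, which makes it the weaker of the pair. Compound 2 `CCCSc1nc(Cl)c2c(n1)N(CCNC(=O)OC(C)(C)C)C(C(=O)N1CCN(C)CC1)N2` gives 12400 nM in this assay, and the gap between the two lies beyond the usual scatter. Compound 3 `CCCSc1nc(Cl)c2c(n1)N(Cc1ccccc1)C(C(=O)NCCCc1ccccc1)N2` differs from compound 1 by a group of 7 heavy atoms (7 carbon; one six-membered aromatic ring of carbon only) in place of a group of 9 heavy atoms (9 carbon; one five-membered non-aromatic ring of carbon only, one six-membered aromatic ring of carbon only), on a saturated chain carbon, two bonds along the chain from an amide-type nitrogen. Going by the values given here, with no measured step of this kind to lean on, the change expected from compound 1 to compound 3 is a 1.2-fold lower number from compound 1 to compound 3 (0.09 log units; within the scatter), a step within the scatter. Compound 3 is therefore estimated at 40000 nM, with a likely range from 15000 nM to 100000 nM.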

Compound 3, half-maximal inhibitory concentration: 9430 nM
Beside the measured number, compound 3's estimate is 4.2-fold (0.63 log units) above it, outside the stated range (below it).
By their numbers in this assay, from the lowest: compounds 3 and 2 (each within the scatter of the next); then compound 1.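

At this place, on a saturated chain carbon, two bonds along the chain from an amide-type nitrogen, benzyl in place of the group with a five-membered non-aromatic ring and a six-membered aromatic ring gives a 5.2-fold lower number from compound 1 to compound 3 (0.71 log units; beyond the scatter) in this assay. So the number here depends on the group at this position, and the five-membered ring is not required for activity at this level. No available evidence explains the shift.

On these data alone, whether a longer chain, an amine or a carboxylic acid at this same place would lower the number further remains open.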